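This account rests on a few compounds, and the source may have more. Where it says the series, first, only, none or still open, it means among the compounds named here.

Compound 1 `Cc1nc(-c2ccc(Cl)cc2)sc1C(=O)CSc1nc(-c2ccccc2)c(C#N)c(=O)[nH]1` gives 41.6% in a functional assay on U-87MG ATCC cells for antiproliferative activity against U-87 MG (Homo sapiens), read by MTT assay, with a stated time of 48 h, tested at 50 uM; on this read-out lower numbers stand for a stronger effect and higher numbers for a weaker effect at the one concentration tested.
Compound 2 `COc1ccc(-c2nc(C)c(C(=O)CSc3nc(-c4cccc(OC)c4)c(C#N)c(=O)[nH]3)s2)cc1` gives 43.2% in this assay.
Compound 3 `COc1ccc(-c2nc(SCC(=O)c3sc(-c4ccc(Cl)cc4)nc3C)[nH]c(=O)c2C#N)cc1` gives 46.3% in this assay.

The three numbers lie within the usual scatter of one another. Compound 3 sits at the upper end of the three in this assay, with compound 2 nearest and compound 1 furthest, and both gaps are within the scatter. Going by the values given here, the one single-point step among the measured compounds, a number 4.7 percentage points higher from compound 1 to compound 3 (within the scatter), is itself within the scatter.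

Compound 4 `COc1cccc(-c2nc(SCC(=O)c3sc(-c4ccc(Cl)cc4)nc3C)[nH]c(=O)c2C#N)c1` is the next compound and has not yet been measured in this assay. It differs from compound 3 by 3-methoxyphenyl in place of 4-methoxyphenyl on an aromatic carbon. Among the compounds with values here, no measured step addresses this change directly. Compound 2 carries the 3-methoxyphenyl group at the same place as compound 4, while differing from it elsewhere, and in this assay compound 2 gives 43.2%, which is within the scatter of compound 3. With every measured difference in this set staying within the scatter, no step beyond the scatter is expected for compound 4 in either direction: the expected step is a number 2.3 percentage points lower from compound 3 to compound 4 (within the scatter). Compound 4 is therefore estimated at 44% in this assay, within a range of 34% to 54%.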

Compound 4, a percentage reported as activity, at one concentration (the size of the read-out at that concentration, not a potency): 47.6%
Beside the measured number, compound 4's estimate is 3.6 percentage points below it; measured number inside the range.
By their numbers in this assay, from the lowest: compounds 1, 2, 3 and 4 (each within the scatter of the next).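

Going by these compounds alone, compound 4 gives the first direct reading of moving the methoxy group on the aromatic carbon next to the ring nitrogen: in this assay, 3-methoxyphenyl in place of 4-methoxyphenyl gives a number 1.3 percentage points higher from compound 3 to compound 4 (within the scatter), so this change does not separate the two compounds. With 3-methoxyphenyl at this place, two further single changes elsewhere also stay within the scatter: chloro in place of methoxy on an aromatic carbon gives a number 4.4 percentage points higher from compound 2 to compound 4 (within the scatter), and methoxy in place of hydrogen on an aromatic carbon gives a number 6 percentage points higher from compound 1 to compound 4 (within the scatter), the latter matching the earlier reading with 4-methoxyphenyl. No available evidence bears on these results.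

All four compounds carry a phenyl group at this place, either unsubstituted or with one methoxy group, so the compounds shown leave open whether an amine or a carboxylic acid on that ring, or a longer alkoxy chain in place of methoxy, would move the number beyond the scatter. They also leave open how these compounds would differ in potency, since each is read at only one concentration.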